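The source may report more compounds than this note shows. Statements on the series, on what has been measured and on what is new or still open speak of the compounds shown alone.

Notes on the series in an ADME assay on CRL8155 cells (Homo sapiens) for cytotoxicity, read by resazurin assay, with a stated time of 72 h; on this read-out lower numbers stand for an effect already at smaller amounts and higher numbers for an effect only at larger amounts of compound.

Compound 1 `O=C(NCCO)Nc1nc2cc(C(=O)c3ccccc3)ccc2[nH]1` in this assay gives only a limit of the assay, > 30000 nM. Compound 2 `CN1CCC(CCn2c(N)nc3ccc(C(=O)c4ccccc4)cc32)CC1` in this assay likewise gives a limit, > 30000 nM. Compound 3 `Nc1nc2ccc(C(=O)c3ccccc3)cc2n1C[C@H]1CCCN1` also gives a limit in this assay, > 30000 nM. Compound 3 thus stands where every measured compound in the series stands, at the limit of the assay, and the step that the two limits leave unreadable from compound 2 to compound 3 cannot be read for size since both of its ends are limits. The whole of the evidence is summed up by the limit of > 30000 nM in this assay, at which 3 of the 3 values shown sit.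

Compound 4 `CN1CCC[C@H]1CCn1c(N)nc2ccc(C(=O)c3ccccc3)cc21` differs from compound 3 in one place: (1-methylpyrrolidin-2-yl)methyl in place of pyrrolidin-2-yl on a saturated chain carbon bound to an aromatic nitrogen. For the measured compounds named here, the only measured step that touches a change at this place is a step that the two limits leave unreadable from compound 2 to compound 3, and its size is not readable. Going by the values given here, no measured step gives a direction, and no compound reaches a readable number. Compound 4 is expected to sit at the limit as well, so the step that the limit leaves unreadable from compound 3 to compound 4 is estimated to be none beyond the scatter. For compound 4 the expected value in this assay is 45000 nM, with a range from 20000 nM to 150000 nM, most probably reported again only as a limit.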

Compound 4, half-maximal effective concentration: > 30000 nM
Compound 4 was reported as a limit; the forecaster's own chance of this, stated with the estimate: 85%; the middle value does not contradict the limit.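

In this assay compound 4 gives only a limit, > 30000 nM. The steps to compound 4 from compound 2 and from compound 3 cannot be read for size, since both ends of each are limits: the limit of > 30000 nM in this assay, at which 4 of the 4 values shown sit.

The compounds shown leave open at what concentration any of them produces an effect, and whether the changes on the chain shift it.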